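From pyridin-2-yl to pyridin-4-yl on a shared core

This account rests on a few compounds, and the source may have more. Where it says the series, first, only, none or still open, it means among the compounds named here.

In a functional assay on RPTEC cells (Homo sapiens) for antiproliferative activity (a higher number here means a weaker inhibitor of growth, a lower number a stronger inhibitor of growth), compound 1 `c1ccc(-c2cc(-c3ccsc3)cc(-c3ccccn3)n2)nc1` gives 0.0047 ug/mL, compound 2 `c1ccc(-c2cc(-c3ccco3)cc(-c3ccccn3)n2)nc1` gives 0.0041 ug/mL, and compound 3 `c1ccc(-c2cc(-c3cccs3)cc(-c3ccccn3)n2)nc1` gives 0.0016 ug/mL, the lowest number of the three. The measured steps all concern one group: a 1.1-fold lower number from compound 1 to compound 2 (0.06 log units; within the scatter), a 2.9-fold lower number from compound 1 to compound 3 (0.47 log units; beyond the scatter) and a 2.6-fold lower number from compound 2 to compound 3 (0.41 log units; beyond the scatter). Compound 4 `c1ccc(-c2cc(-c3cccs3)cc(-c3ccncc3)n2)nc1` keeps the thiophen-2-yl group of compound 3 but carries pyridin-4-yl in place of pyridin-2-yl on an aromatic carbon. Among the measured compounds shown here, no measured step touches that place, so these modest steps offer only a weak guide. A larger change toward a higher number is nonetheless expected, with an estimated 19-fold higher number from compound 3 to compound 4 (1.27 log units; beyond the scatter). For compound 4 the estimated value is 0.03 ug/mL, with an expected range of 0.004 ug/mL to 0.25 ug/mL.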

Compound 4, concentration for 50% growth inhibition: 0.65 ug/mL
Estimate against measurement, compound 4: 22-fold (1.34 log units) below; measured number outside the range, above it.
By their numbers in this assay, from the lowest: compound 3; then compounds 2 and 1 (each within the scatter of the next); then compound 4.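

In this assay, pyridin-4-yl in place of pyridin-2-yl gives a 410-fold higher number from compound 3 to compound 4 (2.61 log units; beyond the scatter), a step far larger than any seen among the thiophen-3-yl, furan-2-yl and thiophen-2-yl compounds. In this one pair, the number depends strongly on how the group at this place is joined, although both groups have the same atoms. Nothing shown here accounts for the size of this step.

As far as these compounds go, whether a pyridin-3-yl or a phenyl group at this place would fall nearer compound 3 or compound 4 remains open. So does whether the step holds with furan-2-yl or thiophen-3-yl in place of thiophen-2-yl.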